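Notes on the step from compound 3 to compound 4

The source may hold more compounds than are shown below. What is called first, only, known or untested is meant among the compounds shown, and "the series" means these compounds.

Measured in a functional assay on MDA-MB-231 cells (Homo sapiens) for cytotoxicity, read by MTT assay, with a stated time of 38 h; on this read-out higher numbers stand for weaker inhibition and lower numbers for stronger inhibition:
- compound 1 `COc1cc(OC)c2c(=O)c(OCC(=O)N/N=C/c3sccc3C)c(-c3cc(OC)c(OC)c(OC)c3)oc2c1`: 4470 nM
- compound 2 `CCN(CC)CCCCOc1c(-c2cc(OC)c(OC)c(OC)c2)oc2cc(OC)cc(OC)c2c1=O`: 13000 nM
- compound 3 `COc1cc(OC)c2c(=O)c(OCCCN3CCN(C)CC3)c(-c3cc(OC)c(OC)c(OC)c3)oc2c1`: 30100 nM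

Compound 3, at 30100 nM, has the highest number of the three. The change to compound 4 `COc1cc(OC)c2c(=O)c(OCC(=O)N/N=C/c3ccco3)c(-c3cc(OC)c(OC)c(OC)c3)oc2c1` is a group of 10 heavy atoms (6 carbon, 2 nitrogen, 2 oxygen; one five-membered aromatic ring with 1 hetero atom) in place of a group of 9 heavy atoms (7 carbon, 2 nitrogen; one six-membered non-aromatic ring with 2 hetero atoms), on a saturated chain carbon bound to an oxygen on an aromatic ring. The entering group holds a five-membered aromatic ring with 1 hetero atom, as does the group on compound 1. The step that bears most is a 6.7-fold higher number from compound 1 to compound 3 (0.83 log units; beyond the scatter), which would run the opposite way here. A smaller related step is a 2.3-fold higher number from compound 2 to compound 3 (0.36 log units; beyond the scatter). In this assay a lower number of similar size to the first step is therefore expected, near compound 1 at 4470 nM. The expected step is a 5.5-fold lower number from compound 3 to compound 4 (0.74 log units; beyond the scatter). The estimate for compound 4 is 5500 nM, with a range of 2000 nM to 15000 nM.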

Compound 4, half-maximal inhibitory concentration: 1860 nM
Compound 4: middle estimate off by 3.0-fold (0.47 log units), on the high side, and the stated range ends above it.
By their numbers in this assay, from the lowest: compound 4; then compound 1; then compound 2; then compound 3.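

In this assay, on a saturated chain carbon bound to an oxygen on an aromatic ring, the group ending in furan-2-yl gives the lowest number of the series, with a 16-fold lower number from compound 3 to compound 4 (1.21 log units; beyond the scatter) and a 7.0-fold lower number from compound 2 to compound 4 (0.84 log units; beyond the scatter). The end of that group also counts: furan-2-yl in place of 3-methylthiophen-2-yl on a carbon with a double bond to nitrogen gives a 2.4-fold lower number from compound 1 to compound 4 (0.38 log units; beyond the scatter). No measurement shown accounts for these steps. Open, from the compounds shown here alone, is how unsubstituted thiophen-2-yl, phenyl or pyridin-3-yl would compare on that carbon, which would separate the effect of the methyl from that of the ring.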